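The source may report more compounds than this note shows. Statements on the series, on what has been measured and on what is new or still open speak of the compounds shown alone.

In a functional assay on L1210 cells (Mus musculus) for cytotoxicity, with a stated time of 48 h (a lower number here means a stronger inhibitor, a higher number a weaker inhibitor), compound 1 `Fc1ccc(-c2nc3sc(Cc4ccc(Cl)cc4)nn3c2Br)cc1` gives > 250000 nM, a limit of the assay rather than a number. Compound 2 `Clc1ccc(Cc2nn3c(Br)c(-c4ccc(Cl)cc4)nc3s2)cc1` differs from it by chloro in place of fluoro on an aromatic carbon and also gives only a limit, > 250000 nM. The step that the two limits leave unreadable from compound 1 to compound 2 therefore cannot be read, both bromo compounds sitting at the limit of > 250000 nM in this assay, at which 2 of the 3 values shown sit. Going by the values given here, compound 3 `N#CSc1c(-c2ccc(F)cc2)nc2sc(Cc3ccc(Cl)cc3)nn12` carries the change cyanosulfanyl in place of bromo on an aromatic carbon and is the one compound here with a number: in this assay compound 3 gives 23000 nM, a step of an at least 10-fold lower number from compound 1 to compound 3 (1.03 log units; beyond the scatter). Compound 4 `N#CSc1c(-c2ccc(Cl)cc2)nc2sc(Cc3ccc(Cl)cc3)nn12` repeats on the core of compound 3 the same change as compound 2, namely (chloro in place of fluoro on an aromatic carbon). The expected step is a 1.2-fold lower number from compound 3 to compound 4 (0.06 log units; within the scatter), set beside a step that the two limits leave unreadable from compound 1 to compound 2, and rests only on that measured pair, which leaves the size unreadable. Compound 4 is accordingly expected to give 20000 nM, between 7000 nM and 60000 nM.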

Compound 4, half-maximal inhibitory concentration: 49000 nM
Compound 4: the middle estimate sits 2.5-fold (0.39 log units) below what was measured, within the range that was stated.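

In this assay, cyanosulfanyl in place of bromo again lowers the number on the second core, with an at least 5.1-fold lower number from compound 2 to compound 4 (0.70 log units; beyond the scatter), and the two cores compare as follows: the same change on two cores in this assay, an at least 10-fold lower number (1.03 log units; beyond the scatter) from compound 1 to compound 3 and an at least 5.1-fold lower number (0.70 log units; beyond the scatter) from compound 2 to compound 4; the limit leaves it open whether they differ The direction of this change therefore carries over between these two cores, but its size does not become readable, as the bromo compounds give only limits: the limit of > 250000 nM in this assay, at which 2 of the 4 values shown sit. Chloro in place of fluoro gives a 2.1-fold higher number from compound 3 to compound 4 (0.33 log units; beyond the scatter), and its counterpart between the bromo compounds cannot be read, so this series does not show whether that step carries over from one core to the other.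

The compounds shown leave open how an amine or a carboxylic acid in place of cyanosulfanyl would compare. They also leave open whether either step would hold on a third core.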